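Methoxy to methylsulfanyl on a compound sitting at the limit

This account rests on a few compounds, and the source may have more. Where it says the series, first, only, none or still open, it means among the compounds named here.

Compound 1, `COc1ccc(CNc2nc([Se]C)nc3ccccc23)cc1`: in a functional assay on MCF7 cells (Homo sapiens) for cytotoxicity, read by MTT assay, with a stated time of 72 h (a higher number here means that more compound is tolerated, a lower number that less compound is tolerated), compound 1 gives > 100000 nM, which is a limit of the assay rather than a number.
Compound 2, `CCCCC[Se]c1nc([Se]CCCCC)c2cccnc2n1`: in this assay compound 2 gives 94600 nM.
Compound 3, `COc1ccc(CNc2nc([SeH])nc3ccccc23)cc1`: in this assay compound 3 gives > 100000 nM, again only a limit.

Compound 3 therefore stands at the limit of > 100000 nM in this assay, at which 2 of the 3 values shown sit. Among the measured compounds shown here, the one single-change step among the measured compounds, a step that the two limits leave unreadable from compound 1 to compound 3, cannot be read in size, since both ends are limits. Compound 2 differs from compound 3 in more than one place, so its value only shows that a reading close to the limit has been obtained once.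

The next compound, compound 4, `CSc1ccc(CNc2nc([SeH])nc3ccccc23)cc1`, is made by one change: methylsulfanyl in place of methoxy on an aromatic carbon. For the measured compounds named here, no measured step involves a methylsulfanyl group or a swap of this kind, so nothing measured bears on it directly. With compound 3 at the limit and no readable step pointing either way, the expectation is no step beyond the scatter, that is a number no higher from compound 3 to compound 4 (the limit leaves the size open), and compound 4 is estimated at 100000 nM, within 40000 nM to 300000 nM.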

Compound 4, concentration lethal to 50% of the cells: > 100000 nM
Compound 4: a limit, no number (the forecaster's own chance of this, stated with the estimate: 65%); the middle value lies on the limit itself.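

Compound 3 and compound 4 each give only a limit in this assay, so the step between them cannot be read in size: the limit of > 100000 nM in this assay, at which 3 of the 4 values shown sit.
The compounds shown leave open whether methylsulfanyl in place of methoxy changes how much compound the cells tolerate.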